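The source may report more compounds than this note shows. Statements on the series, on what has been measured and on what is new or still open speak of the compounds shown alone.

Compound 1: `O=C1NC(=S)S/C1=C\C=C\c1ccccc1OCc1ccncc1` — 62%
Compound 2: `COc1ccccc1/C=C/C=C1\SC(=S)NC1=O` — 69%

In a functional assay on DLD-1 cells (Homo sapiens), read by microscopy and crystal violet staining, with a stated time of 20 h, tested at 10 ug/mL (on this read-out higher numbers stand for more inhibition at the one concentration tested (going by the name of the read-out) and lower numbers for less inhibition), compound 2 gives 69%. For the measured compounds named here, the only other measured compound, compound 1, gives 62%, and the two numbers lie within the scatter of each other, so nothing separates compound 2 from compound 1 on this read-out. Going by the values given here, the single measured step, a number 7 percentage points higher from compound 1 to compound 2 (within the scatter), concerns a change at a different place from the one now considered and is itself within the scatter.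

Compound 3 is `O=C1NC(=S)S/C1=C\C=C\c1ccccc1Cl`, not yet measured. It differs from compound 2 by chloro in place of methoxy on an aromatic carbon. Among the compounds with values here, no measured step exchanges chloro for methoxy, so the only guide is the shared core and the fact that the one change seen so far moved the number by a number 7 percentage points higher from compound 1 to compound 2 (within the scatter), within the scatter. Compound 3 is therefore expected to stay near compound 2, with an expected step of a number 4 percentage points lower from compound 2 to compound 3 (within the scatter). The estimate for compound 3 is 65%, in a range from 40% to 85%.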

Compound 3, a percentage reported as inhibition, at one concentration (the size of the read-out at that concentration, not a potency): 80%
Estimate against measurement, compound 3: 15 percentage points below; low and high end bracket the measured number.
By their numbers in this assay, from the lowest: compounds 1 and 2 (each within the scatter of the next); then compound 3.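

In this assay, for the compounds shown here, the exchange on an aromatic carbon ortho to a large group gives the first step beyond the scatter in this set: a number 11 percentage points higher from compound 2 to compound 3 (beyond the scatter). Replacing the larger ether at the same place gives a similar picture, a number 18 percentage points higher from compound 1 to compound 3 (beyond the scatter), so chloro stands clear of both ether-bearing compounds, whereas the earlier change within the ether left compound 1 and compound 2 within the scatter of each other. The data offer no measured explanation for this rise.

The compounds shown leave open how a bromo group, an amine or a carboxylic acid on the same aromatic carbon would compare, and whether chloro would keep its effect on another carbon of the ring. Each number is also a reading at one concentration, and the potency of these compounds remains open.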